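This account rests on a few compounds, and the source may have more. Where it says the series, first, only, none or still open, it means among the compounds named here.

Measured so far:
compound 1, `CN(C)CCC(=O)Nc1ccc([C@H]2[C@@H](F)[C@@H](F)C[C@@H](F)[C@H]2F)cc1`, 3.7 10^-6 cm/s
compound 2, `NC(=O)CCNC(=O)c1ccc([C@H]2[C@@H](F)[C@@H](F)C[C@@H](F)[C@H]2F)cc1`, 0.4 10^-6 cm/s
compound 3, `COCCC(=O)Nc1ccc([C@H]2[C@@H](F)[C@@H](F)C[C@@H](F)[C@H]2F)cc1`, 18.1 10^-6 cm/s

In an ADME assay on MDCK-MDR1 cells (Canis lupus familiaris) for permeability, in the apical to basolateral direction, with a stated time of 180 min (a lower number here means that the compound crosses the layer more slowly, a higher number that the compound crosses the layer faster), compound 2 stands lowest of the three: the steps of a 9.3-fold lower number from compound 1 to compound 2 (0.97 log units; beyond the scatter) and a 45-fold higher number from compound 2 to compound 3 (1.66 log units; beyond the scatter) place it clearly below both others. Compound 4, `O=C(NCC1CCOCC1)c1ccc([C@H]2[C@@H](F)[C@@H](F)C[C@@H](F)[C@H]2F)cc1`, is not yet measured. It differs from compound 2 by oxan-4-yl in place of carbamoylmethyl on a saturated chain carbon bound to an amide-type nitrogen. The most relevant guide is a 45-fold higher number from compound 2 to compound 3 (1.66 log units; beyond the scatter), where the carbamoyl group likewise left and an ether oxygen came in; a 4.9-fold higher number from compound 1 to compound 3 (0.69 log units; beyond the scatter) also ends at an ether-bearing chain. Compound 4 still carries the aryl-amide of compound 2, so the full gain seen for compound 3 is uncertain. Compound 4 is therefore expected to give about 8 10^-6 cm/s in this assay, with a likely range from 2.5 10^-6 cm/s to 25 10^-6 cm/s. For compound 4 this means an expected step of a 20-fold higher number from compound 2 to compound 4 (1.30 log units; beyond the scatter).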

Compound 4, apparent permeability: 20.3 10^-6 cm/s
For compound 4 the middle estimate is 2.5-fold (0.40 log units) below the measured one, within the range that was stated.
By their numbers in this assay, from the lowest: compound 2; then compound 1; then compounds 3 and 4 (each within the scatter of the next).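

On a saturated chain carbon bound to an amide-type nitrogen, oxan-4-yl in place of carbamoylmethyl gives a 51-fold higher number from compound 2 to compound 4 (1.71 log units; beyond the scatter) in this assay. The low number of compound 2 therefore does not apply to every compound that keeps its aryl-amide link, since compound 4 keeps that link too. No measurement shown explains the step.

This single change removes a hydrogen-bond donor and adds a ring, so the two cannot be told apart. A cyclohexyl group or an open-chain ether such as 2-methoxyethyl at this place would help separate them.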